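The source may hold more compounds than are shown below. What is called first, only, known or untested is meant among the compounds shown, and "the series" means these compounds.

Compound 1 `COc1cc(-n2ncnc2-c2ccc(C)cc2)cc(OC)c1OC`: 1100 nM.
Compound 2 `COc1cccc(-c2ncnn2-c2cc(OC)c(OC)c(OC)c2)c1`: > 10000 nM.
Compound 3 `COc1cc(-n2ncnc2-c2ccccc2)cc(OC)c1OC`: > 10000 nM.

All values come from a functional assay on A549 cells (Homo sapiens) for antiproliferative activity, read by MTT assay, with a stated time of 72 h; a lower number here means a stronger inhibitor, a higher number a weaker inhibitor. The value of compound 3 is a limit and not a number, and the same holds for the value of compound 2: the limit of > 10000 nM in this assay, at which 2 of the 3 values shown sit.

Compound 4 `COc1cc(-n2ncnc2-c2ccc(SC)cc2)cc(OC)c1OC` follows from compound 3 by the change methylsulfanyl in place of hydrogen on an aromatic carbon, para to a large group, so that phenyl becomes 4-(methylsulfanyl)phenyl.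

The closest measured step is an at least 9.0-fold higher number from compound 1 to compound 3 (0.95 log units; beyond the scatter), which removes a methyl group from the same place. A second step, an at least 9.0-fold higher number from compound 1 to compound 2 (0.95 log units; beyond the scatter), also ends at the limit. The third, a step that the two limits leave unreadable from compound 2 to compound 3, gives no size to work with.

Only compound 1 carries a measured group in this place, so the inference rests on one number. A lower number in this assay is expected, by a step of at least modest size. The expected step is an at least 6.6-fold lower number from compound 3 to compound 4 (0.82 log units; beyond the scatter). For compound 4 the estimate is 1500 nM, with an expected range of 250 nM to 9000 nM.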

Compound 4, half-maximal inhibitory concentration: 800 nM
The estimate for compound 4 lay 1.9-fold (0.27 log units) above the measured number, and the stated range covers the measured number.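

With a second measured group para to a large group, the earlier gain no longer rests on methyl alone: methylsulfanyl in place of hydrogen gives an at least 12-fold lower number from compound 3 to compound 4 (1.09 log units; beyond the scatter), and 4-(methylsulfanyl)phenyl in place of 3-methoxyphenyl gives an at least 12-fold lower number from compound 2 to compound 4 (1.09 log units; beyond the scatter). Methylsulfanyl in place of methyl gives a 1.4-fold lower number from compound 1 to compound 4 (0.14 log units; within the scatter), so the two groups cannot be told apart in this assay. Both larger steps start from a limit and not a number, and their sizes are lower bounds only: the limit of > 10000 nM in this assay, at which 2 of the 4 values shown sit.

Going by these compounds, how an amine, a carboxylic acid or a longer chain would read in this place remains open. The compounds shown also leave open whether a group other than methyl or methylsulfanyl would give a number below the limit here.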